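A few compounds are considered here, and "the series" means these few. Any claim that something is new, unique, unknown or untested is made for them only; others in the source may bear on it.

Measured in a functional assay on HCT-116 cells (Homo sapiens) for cytotoxicity, read by MTT assay, with a stated time of 72 h; a higher number here means a weaker inhibitor, a lower number a stronger inhibitor:
compound 1 `CCCC[S+]([O-])CCCCN=C=S`: 2810 nM
compound 2 `CC(C)[S+]([O-])CCCCN=C=S`: 3740 nM
compound 3 `CC(C)C[S+]([O-])CCCCN=C=S`: 2060 nM

The three compounds form a tight set in this assay. Compound 2, at 3740 nM, lies within the scatter of both neighbours, so it cannot be separated from either of them on these numbers.

The next compound to be tested is compound 4 `CC(C)[S+]([O-])CCCCCN=C=S`, which keeps the isopropyl group on the sulfur of compound 2. Its change is a group of 4 heavy atoms (2 carbon, 1 nitrogen, 1 sulfur; no ring) in place of a group of 3 heavy atoms (1 carbon, 1 nitrogen, 1 sulfur; no ring), on a saturated chain carbon, four bonds along the chain from a sulfur. In other words, a group of 4 heavy atoms replaces a group of 3 heavy atoms, on a saturated chain carbon, four bonds along the chain from a sulfur.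

Within the data shown here, no measured step touches this place, so the evidence is only indirect. The steps that exist alter the group on the sulfur side: a 1.3-fold higher number from compound 1 to compound 2 (0.12 log units; within the scatter), a 1.4-fold lower number from compound 1 to compound 3 (0.13 log units; within the scatter) and a 1.8-fold lower number from compound 2 to compound 3 (0.26 log units; within the scatter). All three stay within the scatter, which shows that this set has so far responded little to changes elsewhere in the molecule. They say nothing direct about the new change, so no direction can be argued, and no shift beyond the scatter is expected.

The expected step is a 1.2-fold lower number from compound 2 to compound 4 (0.10 log units; within the scatter). For compound 4 the estimated value is 3000 nM, with an expected range from 1500 nM to 6000 nM.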

Compound 4, half-maximal inhibitory concentration: 3420 nM
Compound 4: the middle estimate sits 1.1-fold (0.06 log units) below what was measured; measured number inside the range.
By their numbers in this assay, from the lowest: compounds 3, 1, 4 and 2 (each within the scatter of the next).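

In this assay, a group of 4 heavy atoms in place of a group of 3 heavy atoms, on a saturated chain carbon, four bonds along the chain from a sulfur, gives a 1.1-fold lower number from compound 2 to compound 4 (0.04 log units; within the scatter), the only step shown at this place. Among these compounds, the earlier steps altered only the sulfur side, so this is the first direct sign that the response is also small at the other end of the molecule, at least with isopropyl on the sulfur. Nothing available accounts for why the numbers stay so close together at this place.

The compounds shown leave open whether a much longer chain, or an amine or a carboxylic acid, at this same place would stay within the scatter of compound 2 or would move the number clearly in either direction. They also leave open whether the same replacement would give an equally small step with butyl or isobutyl on the sulfur, as in compound 1 and compound 3, rather than with isopropyl alone.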